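A methyl-to-phenyl swap in a cytotoxicity series

A few compounds are considered here, and "the series" means these few. Any claim that something is new, unique, unknown or untested is made for them only; others in the source may bear on it.

Compound 1 `O=C(/C=C/c1ccc2c(c1)B(O)OC2)c1ccc(Br)cc1` and compound 2 `Cc1ccc(C(=O)/C=C/c2ccc3c(c2)B(O)OC3)cc1` share a core and differ at one place. In an ADME assay on L929 cells (Mus musculus) for cytotoxicity, read by resazurin assay, with a stated time of 72 h (a lower number here means a stronger inhibitor, a higher number a weaker inhibitor), compound 1 gives > 10 ug/mL as a limit and not a number. In this assay compound 2 gives > 10 ug/mL as a limit too. Compound 2 therefore has no exact value, and the record so far holds only the limit of > 10 ug/mL in this assay, at which 2 of the 2 values shown sit, and no actual number.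

The next compound, compound 3 `O=C(/C=C/c1ccc2c(c1)B(O)OC2)c1ccc(-c2ccccc2)cc1`, carries phenyl in place of methyl on an aromatic carbon, para to a large group (phenyl in place of methyl on an aromatic carbon). Among the compounds with values here, the one measured step that bears on this change is a step that the two limits leave unreadable from compound 1 to compound 2 for methyl in place of bromo on an aromatic carbon, so it offers no size to carry forward. No step beyond the usual scatter is therefore expected in this assay and no direction can be given, so the estimated step is a step that the limit leaves unreadable from compound 2 to compound 3 and nothing more. Compound 3 is expected to land near 12 ug/mL with an estimated range from 5 ug/mL to 30 ug/mL and may well return only a limit again.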

Compound 3, half-maximal inhibitory concentration: > 10 ug/mL
Compound 3: a limit, no number; the forecaster's own chance of this, stated with the estimate: 70%; the middle value is on the limit's open side.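

Within the data shown here, compound 1, compound 2 and compound 3 each return only a limit in this assay, so no step between them can be read, and the three swaps stay without a size: the limit of > 10 ug/mL in this assay, at which 3 of the 3 values shown sit. The compounds shown leave open how strongly any of the three acts in this assay and whether bromo, methyl or phenyl at this place changes that.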